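Swapping the Tetrazole Substituent: Acid Out, Methyl In

The source may hold more compounds than are shown below. What is called first, only, known or untested is meant among the compounds shown, and "the series" means these compounds.

Of the compounds shown here, two have been measured in a functional assay (Pituitary gland cell) with Rattus norvegicus as the target; on this read-out lower numbers stand for an effect already at smaller amounts and higher numbers for an effect only at larger amounts of compound. Compound 1 `CC(O)Cn1nnc(-c2ccccc2-c2ccc(CN3C(=O)[C@H](NC(=O)CC(C)(C)N)CCc4ccccc43)cc2)n1` gives 0.05 uM, and compound 2 `CC(C)(N)CC(=O)N[C@@H]1CCc2ccccc2N(Cc2ccc(-c3ccccc3-c3nnnn3CC(=O)O)cc2)C1=O` gives 1 uM, which is the highest number of the two. Going by the values given here, the only measured step, a 20-fold higher number from compound 1 to compound 2 (1.30 log units; beyond the scatter), shows that exchanging the substituted tetrazole for its carboxymethyl-bearing isomer was accompanied by a marked rise in the number.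

Compound 3 `Cn1nnc(-c2ccccc2-c2ccc(CN3C(=O)[C@H](NC(=O)CC(C)(C)N)CCc4ccccc43)cc2)n1` has not yet been measured in this assay. It differs from compound 2 in one place: 2-methyl-2H-tetrazol-5-yl in place of 1-(carboxymethyl)-1H-tetrazol-5-yl on an aromatic carbon. This change removes the carboxymethyl tetrazole and installs a small, 2-substituted tetrazole, making compound 3 resemble compound 1 in that part of the molecule more than it resembles compound 2.

The step from compound 1 to compound 2 is the only one that bears on this change, and it was large. Because compound 1 gives 0.05 uM, compound 3 is expected to move back toward that value, with a step of a 13-fold lower number from compound 2 to compound 3 (1.10 log units; beyond the scatter) expected in this assay. The estimate for compound 3 is 0.08 uM, with a range from 0.02 uM to 0.4 uM.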

Compound 3, concentration for half-maximal effect: 0.3 uM
Compound 3: the middle estimate sits 3.8-fold (0.57 log units) below what was measured; low and high end bracket the measured number.
By their numbers in this assay, from the lowest: compound 1; then compound 3; then compound 2.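

In this assay, replacing 1-(carboxymethyl)-1H-tetrazol-5-yl with 2-methyl-2H-tetrazol-5-yl gives a 3.3-fold lower number from compound 2 to compound 3 (0.52 log units; beyond the scatter) and recovers only part of the gap seen earlier between the two first compounds. Compound 3 still does not reach compound 1: shortening the side chain on the tetrazole, with hydrogen in place of 1-hydroxyethyl, gives a 6.0-fold higher number from compound 1 to compound 3 (0.78 log units; beyond the scatter), so the low number of compound 1 depends on more than a 2-substituted tetrazole and the 1-hydroxyethyl part of its chain counts as well. Nothing available here explains either shift.

Compound 2 and compound 3 differ both in the group on the tetrazole and in which ring nitrogen carries it, so these compounds cannot say how much of that step belongs to each, and a 1-methyl-1H-tetrazol-5-yl group would be needed to pull the two apart. On these data alone, it also remains open whether a plain propyl chain on the tetrazole would come as close to compound 1 as its hydroxyl-bearing chain does, or whether the hydroxyl group itself is what matters.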